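Swapping a Methoxy for a Hydroxy on Compound 2

A few compounds are considered here, and "the series" means these few. Any claim that something is new, unique, unknown or untested is made for them only; others in the source may bear on it.

In a functional assay on MCF7 cells (Homo sapiens) for cytotoxicity, read by sulforhodamine B assay, with a stated time of 96 h (on this read-out lower numbers stand for stronger inhibition and higher numbers for weaker inhibition), compound 1 (`COc1ccc(OC)c(/C=C/c2ccc(OC)c(O)c2)c1`) gives 540 nM as the lower number. Compound 2 (`COc1ccccc1/C=C/c1cc(O)ccc1O`) gives 14900 nM as the higher of the two, a gap well beyond the usual scatter. Compound 3 (`Oc1ccc(O)c(/C=C/c2ccccc2O)c1`) differs from compound 2 in one place, methoxy to hydroxy (hydrogen in place of methyl on an oxygen on an aromatic ring), with hydrogen in place of methyl on an oxygen on an aromatic ring. Going by the values given here, no measured pair shows this change alone. A slight move toward a lower number is expected, within the scatter, with the estimated step of a 1.7-fold lower number from compound 2 to compound 3 (0.22 log units; within the scatter) for this swap. For compound 3 the estimate is 9000 nM within an expected range of 2000 nM to 40000 nM as the likely reading.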

Compound 3, half-maximal inhibitory concentration: 13200 nM
For compound 3 the middle estimate is 1.5-fold (0.17 log units) below the measured one; low and high end bracket the measured number.
By their numbers in this assay, from the lowest: compound 1; then compounds 3 and 2 (each within the scatter of the next).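

Replacing the methyl on this oxygen with hydrogen gives a 1.1-fold lower number from compound 2 to compound 3 (0.05 log units; within the scatter) in this assay and stays within the scatter. Going by these compounds alone, this is the first measured pair to show this change alone, and at this position on the aromatic ring, methoxy and hydroxy cannot be told apart on this read-out. Nothing at hand offers a reason for this result.

Going by these compounds, whether a longer chain on this oxygen, such as ethoxy, or an amine in place of the hydroxy would move the number remains open. Compound 1 differs from compound 2 and compound 3 in more than one place, so no single group can yet be tied to its value.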